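Fluorophenyl to Chlorophenyl on the Ring Amine

The compounds below may be only part of what the source reports. "The series", "measured", "known", "first", "only" and "open" are said of these compounds alone.

Compound 1 `CCC/C=C/c1c(C)nn(CCCN2CCN(c3ccc(C)cc3)CC2)c(=O)c1N` gives 0% in a functional assay on the whole organism (Abdomen, strain Swiss) for inhibition, with Mus musculus as the target, with stated times of 30 min, 10 min and 5 min, at a dose of 10 mg/kg by the oral route; on this read-out lower numbers stand for a weaker effect and higher numbers for a stronger effect at the one dose given.
Compound 2 `C=Cc1c(C)nn(CCCN2CCN(c3ccc(F)cc3)CC2)c(=O)c1N` gives 0% in this assay.
Compound 3 `O=c1occ(-c2ccccc2)n1CCCN1CCN(c2ccc(F)cc2)CC1` gives 14% in this assay.

Compound 3 stands highest of the three numbers; compound 1 and compound 2 both lie below it by more than the usual scatter, and the two of them sit at the same level. Compound 4 `O=c1occ(-c2ccccc2)n1CCCN1CCN(c2cccc(Cl)c2)CC1` differs from compound 3 in one place: 3-chlorophenyl in place of 4-fluorophenyl on an amine nitrogen in a ring. For the measured compounds named here, no measured pair shows this change, so its size is unknown from the numbers at hand. Since compound 3 itself shows only 14%, the step from compound 3 to compound 4 is expected to be small, a number 2 percentage points lower from compound 3 to compound 4 (within the scatter), within the scatter in either direction. Compound 4 is estimated to give 12% in this assay, between 0% and 30%.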

Compound 4, a percentage reported as inhibition, in the whole organism at one dose (the size of the read-out at that dose, not a potency): 7%
The estimate for compound 4 lay 5 percentage points above the measured number; the measured number falls inside the stated range.
By their numbers in this assay, from the lowest: compounds 1, 2, 4 and 3 (each within the scatter of the next, the first and the last beyond it).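

In this assay the exchange of 4-fluorophenyl for 3-chlorophenyl on the amine nitrogen in the ring gives a number 7 percentage points lower from compound 3 to compound 4 (within the scatter), the first step read at this position, and it shows that this exchange leaves the read-out within the scatter. Both compounds carry the same shared core, so the pair isolates this one place. No measurement at hand offers a cause for this result.

The compounds shown leave open whether a pyridyl or a 4-methoxyphenyl group in this place would move the read-out beyond the scatter of compound 3.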